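The compounds below may be only part of what the source reports. "The series", "measured", "known", "first", "only" and "open" are said of these compounds alone.

Measured compounds:
Compound 1 `C=CC(C)(C)c1cc(-c2ccc(OC)cc2)ccc1O` in a functional assay on HUVEC cells (Homo sapiens) for antiproliferative activity, read by MTT assay, with a stated time of 24 h (a higher number here means a weaker inhibitor, a lower number a stronger inhibitor), gives > 100000 nM, which is a limit of this assay and not a number.
Compound 2 `C=CCc1cc(-c2cccc([N+](=O)[O-])c2)ccc1O` in this assay gives > 100000 nM, again only a limit.
Compound 3 `C=CCc1ccc(OCC(=O)OCC)c(-c2ccc(OCC(=O)OCC)c(CC=C)c2)c1` in this assay gives > 100000 nM, likewise a limit rather than a measured number.

Among the measured compounds shown here, compound 3 therefore stands at the edge of what this assay reports: all three measured values sit at the same limit (the limit of > 100000 nM in this assay, at which 3 of the 3 values shown sit), so none of the three can be placed above or below another, and no step between measured compounds is available.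

The unmeasured compound 4 `C=CCc1cc(C=O)c(OCC(=O)OCC)c(-c2ccc(OCC(=O)OCC)c(CC=C)c2)c1` differs from compound 3 in one place: formyl in place of hydrogen on an aromatic carbon. The change enters a formyl group, with one hydrogen-bond acceptor, on the aromatic carbon ortho to the (ethoxycarbonyl)methoxy group and meta to the allyl group.

For the measured compounds named here, with every measured value resting at the limit, there is no step to draw on. The account expects compound 4 to remain at that limit as well, with a step of a number no higher from compound 3 to compound 4 (the limit leaves the size open) that is expected to lie within the scatter rather than beyond it. Compound 4 is thus estimated at 100000 nM, with a range from 30000 nM to 300000 nM, and the likeliest outcome is that this assay again reports only a limit.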

Compound 4, half-maximal inhibitory concentration: 86900 nM
Beside the measured number, compound 4's estimate is 1.2-fold (0.06 log units) above it; the measured number falls inside the stated range.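

In this assay compound 3 gives > 100000 nM, which is a limit of the assay and not a number. In this assay compound 4 gives 86900 nM. Formyl in place of hydrogen on the aromatic carbon ortho to the (ethoxycarbonyl)methoxy group and meta to the allyl group gives an at least 1.1-fold lower number from compound 3 to compound 4 (0.06 log units; that floor lies within the scatter), a floor that is all that can be said of the size of this step. Compound 4 is thus the only compound shown with a number rather than a limit: the limit of > 100000 nM in this assay, at which 3 of the 4 values shown sit.

The compounds shown leave open whether a carboxylic acid or an aminomethyl group on this same aromatic carbon would read differently from formyl. They also leave open whether formyl would give a number on the core of compound 1 or the core of compound 2.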